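The source may hold more compounds than are shown below. What is called first, only, known or untested is meant among the compounds shown, and "the series" means these compounds.

In a functional assay on HCT-116 cells (Homo sapiens) for inhibition, read by MTT assay, with a stated time of 72 h (on this read-out higher numbers stand for weaker inhibition of growth and lower numbers for stronger inhibition of growth), compound 1 `NC(=O)/C=C/c1ccncc1-c1ccc2ccccc2c1` gives 12100 nM and compound 2 `CN(C)C(=O)/C=C/c1ccncc1-c1ccc2ccccc2c1` gives 4540 nM, so compound 2 holds the lower of the two numbers. Compound 3 `O=C(O)CCc1ccncc1-c1ccc2ccccc2c1` has not yet been measured. It departs from compound 2 by 2-carboxyethyl in place of 2-(dimethylcarbamoyl)ethenyl on an aromatic carbon, with 2-carboxyethyl in place of 2-(dimethylcarbamoyl)ethenyl on an aromatic carbon. Going by the values given here, only one measured step bears on this, and only in part: a 2.7-fold lower number from compound 1 to compound 2 (0.43 log units; beyond the scatter), a modest change confined to the group on the carbonyl carbon. Among the compounds with values here, no measured compound carries a carboxyl group or lacks the chain double bond, so the direction rests on thin evidence and the range must stay wide. A move toward weaker inhibition is expected, somewhat larger than that modest step, with an expected size of a 5.5-fold higher number from compound 2 to compound 3 (0.74 log units; beyond the scatter). Compound 3 is estimated at 25000 nM, within an expected range of 8000 nM to 80000 nM.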

Compound 3, concentration for 50% growth inhibition: > 30000 nM
Compound 3 was reported as a limit; the forecaster's own chance of this, stated with the estimate: 25%; middle value at least 1.2-fold (0.07 log units) away from the limit.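

Going by these compounds alone, until now only the group on the carbonyl carbon had changed; this result is the first to show what happens when the whole chain on this aromatic carbon changes. Putting 2-carboxyethyl in place of 2-(dimethylcarbamoyl)ethenyl gives an at least 6.6-fold higher number from compound 2 to compound 3 (0.82 log units; beyond the scatter), and putting it in place of 2-carbamoylethenyl gives an at least 2.4-fold higher number from compound 1 to compound 3 (0.39 log units; beyond the scatter), so growth inhibition is weaker than with either amide, beyond the scatter in both steps. The reading for compound 3 is a limit and not a number, so the full size of both steps stays unknown: the limit of > 30000 nM in this assay, at which 1 of the 3 values shown sits.

The compounds shown leave open whether the carboxylic acid or the loss of the chain double bond accounts for the change, as the two arrive together. Neither a 2-carboxyethenyl group nor a 2-(dimethylcarbamoyl)ethyl group stands among them to separate the two.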